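This account rests on a few compounds, and the source may have more. Where it says the series, first, only, none or still open, it means among the compounds named here.

Three compounds share one core and differ only in the group attached to the sulfonamide nitrogen's aromatic ring. Compound 1 `O=S(=O)(NCCNc1nccc(-c2c(-c3cccc(F)c3)nc3sccn23)n1)c1ccc(Br)cc1` gives 13500 nM in a functional assay on SK-MEL-28 cells (Homo sapiens) for cytotoxicity, read by MTT assay; on this read-out higher numbers stand for weaker inhibition and lower numbers for stronger inhibition. Compound 2 `O=S(=O)(NCCNc1nccc(-c2c(-c3cccc(F)c3)nc3sccn23)n1)c1ccc(Cl)cc1` gives 18600 nM in this assay. For compound 3 `Cc1ccc(S(=O)(=O)NCCNc2nccc(-c3c(-c4cccc(F)c4)nc4sccn34)n2)cc1` this assay reports only a limit, > 20000 nM, so its exact value is not known. The measured steps are small: a 1.4-fold higher number from compound 1 to compound 2 (0.14 log units; within the scatter), an at least 1.4-fold higher number from compound 1 to compound 3 (0.17 log units; that floor lies within the scatter) and an at least 1.0-fold higher number from compound 2 to compound 3 (0.03 log units; that floor lies within the scatter). Compound 3 therefore stands at the weak end, at the limit of this assay (the limit of > 20000 nM in this assay, at which 1 of the 3 values shown sits).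

Compound 4 `O=C(NCCNc1nccc(-c2c(-c3cccc(F)c3)nc3sccn23)n1)c1ccc(C(F)(F)F)cc1` arises from compound 3 by (4-(trifluoromethyl)phenyl)carbonyl in place of (4-methylphenyl)sulfonyl on an amine nitrogen. For the measured compounds named here, none of the measured steps touches the connecting group; they change only the substituent on the outer ring and lie within the scatter. The expectation for compound 4 is thus a step that the limit leaves unreadable from compound 3 to compound 4, with no clear direction beyond the scatter. Compound 4 is estimated at 22000 nM, within a range from 8000 nM to 60000 nM.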

Compound 4, half-maximal inhibitory concentration: 9260 nM
Estimate against measurement, compound 4: 2.4-fold (0.38 log units) above; the range from low to high includes it.
By their numbers in this assay, from the lowest: compounds 4, 1 and 2 (each within the scatter of the next). At a limit, above all of these: compound 3.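

For the compounds shown here, this result gives the first reading of the connecting group on this amine nitrogen: in this assay, replacing (4-methylphenyl)sulfonyl with (4-(trifluoromethyl)phenyl)carbonyl gives an at least 2.1-fold lower number from compound 3 to compound 4 (0.33 log units; beyond the scatter). That step rests on a limit for compound 3, not on an exact number: the limit of > 20000 nM in this assay, at which 1 of the 4 values shown sits. Against the two compounds with exact values, the change gives a 2.0-fold lower number from compound 2 to compound 4 (0.30 log units; within the scatter) and a 1.5-fold lower number from compound 1 to compound 4 (0.16 log units; within the scatter), so a carbonyl link is tolerated here, but these steps do not show it to be better than a sulfonyl link.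

Each of these steps changes the link and the substituent on the outer ring together, so the compounds shown cannot separate the two changes; (4-methylphenyl)carbonyl on the same nitrogen would do so. Also open, on these data alone, is whether an amine on the outer ring or a longer chain to the shared core would shift the number beyond the scatter.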